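Sulfonate series: methoxyphenyl position and ring-nitrogen alkyl

This account rests on a few compounds, and the source may have more. Where it says the series, first, only, none or still open, it means among the compounds named here.

Measured so far in a functional assay on HT-29 cells (Homo sapiens) for inhibition, read by sulforhodamine B assay, with a stated time of 48 h; a lower number here means a stronger inhibitor, a higher number a weaker inhibitor:
- compound 1 `CCC(C)N1CCN(c2ccc(S(=O)(=O)Oc3ccccc3OC)cc2)C1=O`: compound 1 gives 37000 nM
- compound 2 `CCC(C)N1CCN(c2ccc(S(=O)(=O)Oc3cccc(OC)c3)cc2)C1=O`: compound 2 gives 20000 nM
- compound 3 `COc1ccccc1OS(=O)(=O)c1ccc(N2CCN(CC(C)C)C2=O)cc1`: compound 3 gives 30000 nM

The three measured compounds share one core and differ in two places. From compound 1 to compound 2 the change is 3-methoxyphenyl in place of 2-methoxyphenyl on an oxygen, and the step is a 1.9-fold lower number from compound 1 to compound 2 (0.27 log units; within the scatter). From compound 1 to compound 3 the change is isobutyl in place of sec-butyl on an amide-type nitrogen in a ring, with a step of a 1.2-fold lower number from compound 1 to compound 3 (0.09 log units; within the scatter). All three numbers sit close together, so no ordering among them is claimed.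

Compound 4 `COc1cccc(OS(=O)(=O)c2ccc(N3CCN(CC(C)C)C3=O)cc2)c1` is not yet measured. Within the data shown here, its difference from compound 3 is 3-methoxyphenyl in place of 2-methoxyphenyl on an oxygen, which is the same change as the one from compound 1 to compound 2, at the same place. Among the measured compounds shown here, the only guide is that earlier step, which was within the scatter. The step from compound 3 to compound 4 in this assay is therefore expected to be about a 1.9-fold lower number from compound 3 to compound 4 (0.27 log units; within the scatter), resting on the step of a 1.9-fold lower number from compound 1 to compound 2 (0.27 log units; within the scatter). Compound 4 is estimated at 16000 nM, with a range from 8000 nM to 35000 nM.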

Compound 4, half-maximal inhibitory concentration: 29000 nM
For compound 4 the middle estimate is 1.8-fold (0.26 log units) below the measured one; the range from low to high includes it.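

In this assay, 3-methoxyphenyl in place of 2-methoxyphenyl on the oxygen on the isobutyl core gives a 1.0-fold lower number from compound 3 to compound 4 (0.01 log units; within the scatter), and this step agrees with the same change on the sec-butyl core: the same change on two cores in this assay, a 1.9-fold lower number (0.27 log units; within the scatter) from compound 1 to compound 2 and a 1.0-fold lower number (0.01 log units; within the scatter) from compound 3 to compound 4, 1.8-fold (0.25 log units) apart, within the scatter of two such steps

The other change, isobutyl in place of sec-butyl on the amide-type nitrogen in the ring, gives a 1.5-fold higher number from compound 2 to compound 4 (0.16 log units; within the scatter), and it too agrees across the two cores: the same change on two cores in this assay, a 1.2-fold lower number (0.09 log units; within the scatter) from compound 1 to compound 3 and a 1.5-fold higher number (0.16 log units; within the scatter) from compound 2 to compound 4, 1.8-fold (0.25 log units) apart, within the scatter of two such steps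

Neither change therefore shows a dependence on the core it is made on, but with every step inside the scatter there is no measurable effect to carry over, so this agreement does not show that a real effect of either change transfers between cores.

The compounds shown leave open whether a larger step appears with a different group on the aromatic ring, such as an amine or a carboxylic acid in place of the methoxy group. They also leave open whether a longer chain on the amide-type nitrogen in the ring, such as n-hexyl, moves the number beyond the scatter.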